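Methyl on the Ring Amine, Tried a Second Time

The source may report more compounds than this note shows. Statements on the series, on what has been measured and on what is new or still open speak of the compounds shown alone.

Compound 1 `CCn1cc(-c2nc3ccccc3[nH]2)c(=O)c2cc(F)c(N3CCNCC3)cc21` is the reference point: in a functional assay on KB cells (Homo sapiens) for cytotoxicity, read by MTT assay, with a stated time of 48 h (a lower number here means a stronger inhibitor, a higher number a weaker inhibitor), compound 1 gives 10500 nM. Compound 2 `CCn1cc(-c2nc3ccccc3[nH]2)c(=O)c2cc(F)c(N3CCN(C)CC3)cc21` carries methyl in place of hydrogen on an amine nitrogen in a ring, and compound 2 gives 36700 nM, a step of a 3.5-fold higher number from compound 1 to compound 2 (0.54 log units; beyond the scatter). Compound 3 `CCn1cc(-c2nc3ccc(N)cc3[nH]2)c(=O)c2cc(F)c(N3CCNCC3)cc21` instead carries amino in place of hydrogen on an aromatic carbon, and compound 3 gives 35400 nM, a step of a 3.4-fold higher number from compound 1 to compound 3 (0.53 log units; beyond the scatter). Compound 4 `CCn1cc(-c2nc3ccc(N)cc3[nH]2)c(=O)c2cc(F)c(N3CCN(C)CC3)cc21` has not been measured in this assay; it differs from compound 3 by methyl in place of hydrogen on an amine nitrogen in a ring, the same change seen from compound 1 to compound 2, while the two cores differ by amino in place of hydrogen on an aromatic carbon. Among the compounds with values here, the expected step is a 3.1-fold higher number from compound 3 to compound 4 (0.49 log units; beyond the scatter), resting on the single earlier step of a 3.5-fold higher number from compound 1 to compound 2 (0.54 log units; beyond the scatter), with the caveat that only one example of this change exists here. Compound 4 is therefore estimated at 110000 nM, within 40000 nM to 280000 nM.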

Compound 4, half-maximal inhibitory concentration: > 50000 nM
Compound 4 gave a limit, no number; the forecaster's own chance of this, stated with the estimate: 25%; the middle value lies beyond the limit too.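

In this assay compound 4 gave only a limit, > 50000 nM, and not a number. On the amino-bearing core, methyl in place of hydrogen on the ring amine gives a step of an at least 1.4-fold higher number from compound 3 to compound 4 (0.14 log units; that floor lies within the scatter), which is only a floor, so it fits the earlier rise but does not show that the size of the step carries over: the same change on two cores in this assay, a 3.5-fold higher number (0.54 log units; beyond the scatter) from compound 1 to compound 2 and an at least 1.4-fold higher number (0.14 log units; that floor lies within the scatter) from compound 3 to compound 4; the limit leaves it open whether they differ. Amino in place of hydrogen, read on the core of compound 2, gives a step of an at least 1.3-fold higher number from compound 2 to compound 4 (0.13 log units; that floor lies within the scatter), another floor that leaves the carry-over of this change equally unsettled: the same change on two cores in this assay, a 3.4-fold higher number (0.53 log units; beyond the scatter) from compound 1 to compound 3 and an at least 1.3-fold higher number (0.13 log units; that floor lies within the scatter) from compound 2 to compound 4; the limit leaves it open whether they differ.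

The compounds shown leave open how an ethyl or acetyl group on the ring nitrogen would read. They also leave open whether a hydroxyl or nitro group in the place of the amino group would give a similar step.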